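Replacing dimethylamino with chloro on the shared core

The source may hold more compounds than are shown below. What is called first, only, known or untested is meant among the compounds shown, and "the series" means these compounds.

Compound 1 `COc1ccc(C(=O)/C=C/c2ccc(N(C)C)cc2)c2c1C=CC(C)(C)O2` holds the lowest of the two numbers given in a functional assay on HepG2 cells (Homo sapiens) for antiproliferative activity, read by MTT assay, with a stated time of 24 h (on this read-out higher numbers stand for weaker inhibition and lower numbers for stronger inhibition), where compound 1 gives 730 nM. Compound 2 `COc1ccc(C(=O)/C=C/c2ccc3ccccc3n2)c2c1C=CC(C)(C)O2` gives 4280 nM in this assay, a gap beyond the scatter. For compound 3 `COc1ccc(C(=O)/C=C/c2cccc(C(F)(F)F)c2)c2c1C=CC(C)(C)O2` this assay reports only a limit, > 10000 nM; (the limit of > 10000 nM in this assay, at which 1 of the 3 values shown sits). Compound 4 `COc1ccc(C(=O)/C=C/c2ccc(Cl)cc2)c2c1C=CC(C)(C)O2` differs from compound 1 by chloro in place of dimethylamino on an aromatic carbon. Going by the values given here, no pair of measured compounds differs in one place, so the size of such a step is untested here. A weakening beyond the scatter is nevertheless expected, given that compound 2 gives 4280 nM once the dimethylamino-bearing ring is gone. Compound 4 is expected at 3000 nM, within 900 nM to 10000 nM. The expected step is a 4.1-fold higher number from compound 1 to compound 4 (0.61 log units; beyond the scatter).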

Compound 4, half-maximal inhibitory concentration: > 10000 nM
Compound 4: only a limit was reported (the forecaster's own chance of this, stated with the estimate: 20%); middle value at least 3.3-fold (0.52 log units) away from the limit.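

Read in this assay, the change from 4-(dimethylamino)phenyl to 4-chlorophenyl gives the first single-place step in the series, and it is large: an at least 13-fold higher number from compound 1 to compound 4 (1.13 log units; beyond the scatter). Compound 4 gives > 10000 nM, which is a limit of the assay, so the step has a floor but no measured size. Such limits are common in this small set: the limit of > 10000 nM in this assay, at which 2 of the 4 values shown sit.

Still open, going by these compounds, is whether the nitrogen or its two methyl groups carry the difference. An unsubstituted amino, diethylamino or methoxy group at this place on the shared core would separate these readings.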